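Moving the Chlorine on a Hydrazone Series

A few compounds are considered here, and "the series" means these few. Any claim that something is new, unique, unknown or untested is made for them only; others in the source may bear on it.

Measured so far:
compound 1, `COc1ccc(/C=N/NC(=O)c2ccc(-c3ccc(Cl)cc3)nc2C)cc1OC`, 443 ug/mL
compound 2, `COc1cc(/C=N/NC(=O)c2ccc(-c3ccc(Cl)cc3)nc2C)cc(OC)c1OC`, 41.1 ug/mL
compound 3, `COc1cccc(/C=N/NC(=O)c2ccc(-c3ccc(Cl)cc3)nc2C)c1O`, 500 ug/mL

All three were tested in an ADME assay on WI-38 cells (Homo sapiens) for cytotoxicity, read by colorimetric assay and crystal violet staining, with a stated time of 24 h; a lower number here means a stronger inhibitor, a higher number a weaker inhibitor. Compound 1 sits second highest of the three numbers: compound 3 is its nearest neighbour, and the two lie within the usual scatter of each other, so no order between them can be read. Among the measured compounds shown here, compound 2 is the outlier, and the single one-change step in the set, an 11-fold lower number from compound 1 to compound 2 (1.03 log units; beyond the scatter), describes that gap.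

Compound 4, `COc1ccc(/C=N/NC(=O)c2ccc(-c3cccc(Cl)c3)nc2C)cc1OC`, differs from compound 1 by 3-chlorophenyl in place of 4-chlorophenyl on an aromatic carbon. The change sits on an aromatic carbon of the six-membered ring with one nitrogen, next to the ring nitrogen, meta to a methyl group and para to a large group. For the measured compounds named here, no measured step touches this chlorophenyl ring; the one step known concerns a methoxy on the other ring, and compound 3 alters that ring too. Nothing in these data therefore points to a shift either way, and the expectation is no step beyond the scatter.

For compound 4 the expected step is a 1.0-fold lower number from compound 1 to compound 4 (0.00 log units; within the scatter). Compound 4 is estimated at 440 ug/mL, with a range from 200 ug/mL to 900 ug/mL.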

Compound 4, half-maximal inhibitory concentration: 168 ug/mL
Estimate against measurement, compound 4: 2.6-fold (0.42 log units) above; measured number outside the range, below it.
By their numbers in this assay, from the lowest: compound 2; then compound 4; then compounds 1 and 3 (each within the scatter of the next).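

Moving the chlorine, with the same atoms simply joined differently, gives a 2.6-fold lower number from compound 1 to compound 4 (0.42 log units; beyond the scatter) in this assay, so the place of the chlorine on this ring matters to the number. Among the compounds shown here, until now the only step that could be read lay on the other aromatic ring, the one carrying the methoxy groups, and this is the first to show that the chlorophenyl ring can shift the result as well. No measurement shown here offers an explanation for this shift.

The compounds shown leave open whether a different group on this ring, such as a fluorine, a nitrile or an amine, would shift the number in the same direction. They also leave open whether 3-chlorophenyl in place of 4-chlorophenyl would give a similar step on compound 2 or compound 3.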